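The source may report more compounds than this note shows. Statements on the series, on what has been measured and on what is new or still open speak of the compounds shown alone.

Compound 1, `CCCCCCCCC(=O)N1c2ccccc2CCC1C(=O)Nc1ccccc1C(F)(F)F`, gives 4320 nM in a functional assay on PC-3 cells (Homo sapiens) for cytotoxicity, read by sulforhodamine B assay, with a stated time of 72 h; a lower number here means a stronger inhibitor of growth, a higher number a weaker inhibitor of growth.
Compound 2, `O=C(Nc1cc(C(F)(F)F)cc(C(F)(F)F)c1)C1CCc2ccccc2N1C(=O)c1ccc(Cl)cc1`, gives 4230 nM in this assay.
Compound 3, `CC(=O)N1c2ccccc2CCC1C(=O)Nc1cc(C(F)(F)F)cc(C(F)(F)F)c1`, gives > 70000 nM in this assay.

The value of compound 3 in this assay is a limit of the assay, not a number, so compound 3 stands at the limit of > 70000 nM in this assay, at which 1 of the 3 values shown sits, and its true growth inhibition is weaker than anything else shown. Compound 4, `O=C(Nc1cc(C(F)(F)F)cc(C(F)(F)F)c1)C1CCc2ccccc2N1C(=O)c1cccc(Cl)c1`, is not yet measured. The change from compound 3 to compound 4 is 3-chlorophenyl in place of methyl on a carbonyl carbon. Within the data shown here, one measured step bears on it, in the opposite direction: an at least 16-fold higher number from compound 2 to compound 3 (1.21 log units; beyond the scatter). Reversing a change of that kind is expected to give a large drop, an at least 14-fold lower number from compound 3 to compound 4 (1.14 log units; beyond the scatter), in this assay. The estimate for compound 4 is 5000 nM, with a range from 1500 nM to 20000 nM.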

Compound 4, concentration for 50% growth inhibition: 1050 nM
The estimate for compound 4 lay 4.8-fold (0.68 log units) above the measured number; the whole stated range lies above it.
By their numbers in this assay, from the lowest: compound 4; then compounds 2 and 1 (each within the scatter of the next). At a limit, above all of these: compound 3.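

Compound 3 stands at a limit of the assay, not at a number: the limit of > 70000 nM in this assay, at which 1 of the 4 values shown sits.

In this assay, replacing acetyl with (3-chlorophenyl)carbonyl gives an at least 66-fold lower number from compound 3 to compound 4 (1.82 log units; beyond the scatter), so the large gain on this carbonyl carbon is not confined to a 4-chlorophenyl group. Where the chlorine sits on the ring also matters, as moving from 4-chlorophenyl to 3-chlorophenyl gives a 4.0-fold lower number from compound 2 to compound 4 (0.61 log units; beyond the scatter).

From the compounds shown here alone, what remains open is whether the chlorine is needed at all, which an unsubstituted phenyl would test, and how a 3-methoxyphenyl or 3-aminophenyl group would compare on this carbonyl carbon.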